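The compounds below may be only part of what the source reports. "The series", "measured", "known", "first", "only" and "open" are said of these compounds alone.

The series shares the core of compound 1 `O=C(Nc1nnc(-c2ccc3c(c2)OCCO3)s1)c1ccccc1`, which in a functional assay on BGC-823 cells (Homo sapiens) for antiproliferative activity, read by MTT assay, with a stated time of 48 h (a lower number here means that less compound is needed, a higher number that more compound is needed for the effect), gives 46.2 ug/mL. Compound 2 `Cc1ccccc1C(=O)Nc1nnc(-c2ccc3c(c2)OCCO3)s1` reaches only the limit of this assay, > 100 ug/mL, a limit and not a number. Compound 3 `O=C(Nc1nnc(-c2ccc3c(c2)OCCO3)s1)c1ccc(Cl)nc1` likewise returns only a limit in this assay, > 100 ug/mL, so compound 3 stands at a bound rather than at a value (the limit of > 100 ug/mL in this assay, at which 2 of the 3 values shown sit). The readable step is an at least 2.1-fold higher number from compound 1 to compound 3 (0.33 log units; beyond the scatter); the step that the two limits leave unreadable from compound 2 to compound 3. Compound 4 `O=C(Nc1nnc(-c2ccc3c(c2)OCCO3)s1)c1ccccn1` differs from compound 3 by pyridin-2-yl in place of 6-chloropyridin-3-yl on a carbonyl carbon. Within the data shown here, no measured step covers this exchange directly; an at least 2.1-fold higher number from compound 1 to compound 3 (0.33 log units; beyond the scatter) shows that exchanging phenyl raised the number, and compound 4 keeps a pyridin-2-yl. Compound 4 is therefore expected near the limit, estimated at 90 ug/mL (range 30 ug/mL to 250 ug/mL), which would mean an at least 1.1-fold lower number from compound 3 to compound 4 (0.04 log units; that floor lies within the scatter).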

Compound 4, half-maximal effective concentration: 35.8 ug/mL
Estimate against measurement, compound 4: 2.5-fold (0.40 log units) above, within the range that was stated.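

Exchanging 6-chloropyridin-3-yl for pyridin-2-yl on the carbonyl carbon gives an at least 2.7-fold lower number from compound 3 to compound 4 (0.44 log units; beyond the scatter), and exchanging 2-methylphenyl for it gives an at least 2.7-fold lower number from compound 2 to compound 4 (0.44 log units; beyond the scatter). A pyridine ring at this position therefore does not by itself send the value to the limit, as compound 3 does and compound 4 does not, and a 1.3-fold lower number from compound 1 to compound 4 (0.11 log units; within the scatter) leaves pyridin-2-yl and phenyl unseparated. Both larger steps are floors set by limits: the limit of > 100 ug/mL in this assay, at which 2 of the 4 values shown sit.

Open, on these data alone, is how pyridin-3-yl without the chlorine would read in this assay. Also open, as far as these compounds go, is how an amine on the pyridin-2-yl would read there.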